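This account rests on a few compounds, and the source may have more. Where it says the series, first, only, none or still open, it means among the compounds named here.

Compound 1 `Fc1cccc(-c2nc(Nc3ccccc3)c3cc(F)ccc3n2)c1`: 47600 nM
Compound 2 `Fc1cccc(-c2nc(Nc3ccccc3Cl)c3cc(F)ccc3n2)c1`: > 50000 nM
Compound 3 `Fc1cccc(-c2nc(Nc3ccc(Br)cc3)c3cc(F)ccc3n2)c1`: > 50000 nM

In a functional assay on U2OS cells (Homo sapiens) for cytotoxicity, read by MTT assay, with a stated time of 48 h (on this read-out lower numbers stand for stronger inhibition and higher numbers for weaker inhibition), compound 1 gives 47600 nM. For compound 2 the value > 50000 nM is a limit of the assay, not a number. For compound 3 the value > 50000 nM is likewise a limit, so compound 3 stands at the limit of > 50000 nM in this assay, at which 2 of the 3 values shown sit. The steps of an at least 1.0-fold higher number from compound 1 to compound 2 (0.02 log units; that floor lies within the scatter) and an at least 1.0-fold higher number from compound 1 to compound 3 (0.02 log units; that floor lies within the scatter) are both floors that lie within the scatter, and the step that the two limits leave unreadable from compound 2 to compound 3 cannot be read. Compound 4 `Fc1cccc(-c2nc(Nc3cccc(Br)c3)c3cc(F)ccc3n2)c1` differs from compound 3 by 3-bromophenyl in place of 4-bromophenyl on a nitrogen on an aromatic ring. Within the data shown here, no measured step reads the shift of a bromine around that ring, so in this assay no step beyond the scatter is expected, and compound 4 is estimated at 50000 nM (range 20000 nM to 120000 nM), an expected step of a number no higher from compound 3 to compound 4 (the limit leaves the size open).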

Compound 4, half-maximal inhibitory concentration: > 50000 nM
Compound 4: no number, only a limit; the forecaster's own chance of this, stated with the estimate: 70%; the middle value sits exactly at the limit.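

In this assay, among these compounds, 3-bromophenyl in place of 4-bromophenyl leaves the compound at the limit, so a second placing of the bromine on this ring gives no measurable number either: the limit of > 50000 nM in this assay, at which 3 of the 4 values shown sit. The only step that can be read is an at least 1.0-fold higher number from compound 1 to compound 4 (0.02 log units; that floor lies within the scatter). The steps to compound 4 from compound 2 and from compound 3 join two limits and cannot be read.

The compounds shown leave open whether a methoxy group, an amine or a carboxylic acid on this phenyl ring would give a number clearly lower than that of compound 1. Going by these compounds, how far compound 2, compound 3 and compound 4 lie beyond the limit also stays open.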